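Bromo to trifluoromethyl on the aryl of compound 1

The source may report more compounds than this note shows. Statements on the series, on what has been measured and on what is new or still open speak of the compounds shown alone.

Compound 1 `Clc1ccc(CO/N=C/c2c(-c3ccc(Br)cc3)nc3sccn23)cc1Cl` is the reference point of this set. In an assay on HepG2 cells for agonist activity at nuclear receptor subfamily 1 group I member 3 (Homo sapiens), read by a luciferase reporter, with a stated time of 23 h (on this read-out higher numbers stand for an effect only at larger amounts of compound and lower numbers for an effect already at smaller amounts), compound 1 gives 480 nM, the lowest of the two numbers reported. The nearest entry is compound 3 `Clc1ccccc1CO/N=C/c1c(-c2ccc3ccccc3c2)nc2occn12`, which in this assay gives 1100 nM, a gap that lies beyond the usual scatter; compound 3 also differs from compound 1 in more than one place, so no single step can be read from the pair. Compound 2 `CC1(C)CCC(C)(C)c2cc(-c3nc4sccn4c3/C=N/OCc3ccc(Cl)c(Cl)c3)ccc21` is reported in this assay as "not active" (no number reported), without a number.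

Compound 4 `FC(F)(F)c1ccc(-c2nc3sccn3c2/C=N/OCc2ccc(Cl)c(Cl)c2)cc1` has not yet been measured. It differs from compound 1 by trifluoromethyl in place of bromo on an aromatic carbon. Within the data shown here, no step between two measured compounds in this set isolates that change, so the expectation rests on the value of compound 1 alone. The step from compound 1 to compound 4 is expected to be a 1.4-fold higher number from compound 1 to compound 4 (0.13 log units; within the scatter), a small shift that may well stay within the scatter, if anything toward a higher number. Compound 4 is estimated at 650 nM, with a range from 250 nM to 1700 nM.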

Compound 4, half-maximal effective concentration: 880 nM
Compound 4: the middle estimate sits 1.4-fold (0.13 log units) below what was measured; the measured number falls inside the stated range.
By their numbers in this assay, from the lowest: compounds 1, 4 and 3 (each within the scatter of the next, the first and the last beyond it).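

In this assay, among these compounds, trifluoromethyl in place of bromo on the aromatic carbon gives a 1.8-fold higher number from compound 1 to compound 4 (0.26 log units; within the scatter) and provides the first readable single-place step. At this place on the six-membered aromatic ring, the exchange of 4-bromophenyl for 4-(trifluoromethyl)phenyl therefore leaves the two numbers within the scatter of each other, and compound 4 keeps a number, whereas compound 2, with a different aryl group on the same remainder, is reported as not active. No supporting measurement accompanies this step, so the result stands without an explanation.

Going by these compounds, whether a methoxy group, an amine or a carboxylic acid at the same place would also stay within the scatter of compound 1 remains open. Also open, on these data alone, is whether the same exchange would read alike with a different group at the other end of compound 1.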